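This account rests on a few compounds, and the source may have more. Where it says the series, first, only, none or still open, it means among the compounds named here.

Compound 1 `CCOC(=O)c1ccc2[nH]c(-c3ccc(Cl)cc3)c(Oc3ccc(Cl)cc3)c2c1` gives 28000 nM in a functional assay on A549 cells (Homo sapiens) for inhibition, read by MTT assay, with a stated time of 72 h; a lower number here means a stronger inhibitor of growth, a higher number a weaker inhibitor of growth. Compound 2 `O=C(COc1ccc(Cl)cc1)Nc1c(-c2ccccc2)[nH]c2ccccc12` gives 37000 nM in this assay. Compound 3 `CCOC(=O)C1CCN(C(=S)Sc2c(-c3ccc(Br)cc3)[nH]c3ccc(Cl)cc23)CC1` gives 34000 nM in this assay.

All three numbers lie close together. The number of compound 2 sits nearest to that of compound 3, and its gap to compound 1 is also within the usual scatter of this kind of measurement, so none of the three can be told apart as a stronger or weaker inhibitor of growth. No pair of these compounds differs in only one place, so no single structural step can be read off from the measured values.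

Compound 4 `O=C(CSCc1ccccc1)Nc1c(-c2ccccc2)[nH]c2ccccc12` is the next compound and has not yet been measured in this assay. It differs from compound 2 in one place: benzylsulfanyl in place of 4-chlorophenoxy on a saturated chain carbon bound to a carbonyl carbon. For the measured compounds named here, with no comparable step among the measured compounds to lean on, the expectation is a step from compound 2 to compound 4 of a 1.1-fold lower number from compound 2 to compound 4 (0.02 log units; within the scatter), that is, nothing beyond the scatter. For compound 4 the estimate is 35000 nM, within a range from 15000 nM to 80000 nM.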

Compound 4, concentration for 50% growth inhibition: 30000 nM
The estimate for compound 4 lay 1.2-fold (0.07 log units) above the measured number; the range from low to high includes it.
By their numbers in this assay, from the lowest: compounds 1, 4, 3 and 2 (each within the scatter of the next).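

In this assay, for the compounds shown here, the step of a 1.2-fold lower number from compound 2 to compound 4 (0.09 log units; within the scatter) is the first change that can be read at a single place, here on a saturated chain carbon bound to a carbonyl carbon. Benzylsulfanyl and 4-chlorophenoxy have the same heavy-atom count, and each holds one six-membered aromatic ring of carbon only, yet they differ in carrying sulfur or oxygen and chlorine; at this position, this exchange leaves the number within the scatter. Nothing measured here gives a reason for this result.

From the compounds shown here alone, both groups carry an aromatic ring and no net charge, so it remains open whether an amine, a carboxylic acid or a longer chain at this place would move the number beyond the scatter. Going by these compounds, it also remains open whether this same exchange would read alike on a different core.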